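The source may hold more compounds than are shown below. What is called first, only, known or untested is meant among the compounds shown, and "the series" means these compounds.

Measured so far:
compound 1 `CC[C@H](C)[C@@H](CN(C(=O)[C@@H]1C[C@H]1c1ccccc1)c1ccc(-c2ccccc2)cc1)NC(C)=O` — 5.8 nM
compound 2 `CC[C@@H](C)[C@H](N)CN(C(=O)[C@@H]1C[C@H]1c1ccccc1)c1ccc(-c2ccccc2)cc1` — 1.4 nM
compound 3 `CO[C@H](C)[C@H](N)CN(C(=O)[C@@H]1C[C@H]1c1ccccc1)c1ccc(-c2ccccc2)cc1` — 0.68 nM

All values come from a functional assay for agonist activity at G protein-coupled receptor 88 (Homo sapiens), read by HTRF and cAMP accumulation; on this read-out lower numbers stand for an effect already at smaller amounts and higher numbers for an effect only at larger amounts of compound. Compound 2 stands second highest of the three numbers: its nearest neighbour is compound 3, reached by a 2.1-fold lower number from compound 2 to compound 3 (0.31 log units; beyond the scatter), its furthest is compound 1, separated from it by a 4.1-fold lower number from compound 1 to compound 2 (0.62 log units; beyond the scatter). For the measured compounds named here, compound 1 is the only compound with the acetylated nitrogen, and both free-amine compounds give lower numbers than it, compound 3 also by an 8.5-fold lower number from compound 1 to compound 3 (0.93 log units; beyond the scatter).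

Compound 4 `O=C([C@@H]1C[C@H]1c1ccccc1)N(CCNCC1CCCCC1)c1ccc(-c2ccccc2)cc1` is not yet measured. Relative to compound 2 the change is ((cyclohexylmethyl)amino)methyl in place of 1-amino-2-methylbutyl on a saturated chain carbon bound to an amide-type nitrogen. The free amine is kept, but the sec-butyl branch and both stereocentres go, and the nitrogen now carries a cyclohexylmethyl group. Going by the values given here, no measured step alters the nitrogen substitution in this way; the step from compound 1 to compound 2 shows that an acetylated nitrogen costs, and the step from compound 2 to compound 3 shows the side chain matters only modestly. A larger change than any measured one is involved, so a modest rise in number is expected, a 4.3-fold higher number from compound 2 to compound 4 (0.63 log units; beyond the scatter), with the estimate for compound 4 at 6 nM (range 1.2 nM to 35 nM).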

Compound 4, half-maximal effective concentration: 6.6 nM
Compound 4: the middle estimate sits 1.1-fold (0.04 log units) below what was measured; low and high end bracket the measured number.
By their numbers in this assay, from the lowest: compound 3; then compound 2; then compounds 1 and 4 (each within the scatter of the next).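

In this assay, replacing 1-amino-2-methylbutyl with ((cyclohexylmethyl)amino)methyl gives a step beyond the scatter (a 4.7-fold higher number from compound 2 to compound 4 (0.67 log units; beyond the scatter)), and replacing 1-amino-2-methoxypropyl with the same group gives a similar result (a 9.7-fold higher number from compound 3 to compound 4 (0.99 log units; beyond the scatter)). Keeping an unacylated amine at this position is therefore not enough for the low numbers of compound 2 and compound 3, since compound 4 lies within the scatter of the acetylated compound (a 1.1-fold higher number from compound 1 to compound 4 (0.06 log units; within the scatter)). No supporting measurement bears on the reason for these steps.

The change removes the branch and both stereocentres while adding cyclohexylmethyl on the nitrogen, so the contribution of each remains unseparated. A plain 2-aminoethyl group, or cyclohexylmethyl on the nitrogen of 1-amino-2-methylbutyl, would leave open questions that these compounds cannot settle on their own.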